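The compounds below may be only part of what the source reports. "The series", "measured", "known", "first", "only" and "open" are said of these compounds alone.

Compound 1 `CC1(COCc2ccc(OCc3ccccc3)cc2)Cn2cc([N+](=O)[O-])nc2S1` — > 10 ug/mL.
Compound 2 `O=[N+]([O-])c1cn2c(n1)OC[C@@H](NCc1ccc(OC(F)(F)F)cc1)C2` — > 10 ug/mL.
Compound 3 `O=[N+]([O-])c1cn2c(n1)[S@@+]([O-])C[C@@H](OCc1ccc(OC(F)(F)F)cc1)C2` — > 10 ug/mL.

All three values come from an ADME assay on L929 cells (Mus musculus) for cytotoxicity; on this read-out lower numbers stand for stronger inhibition and higher numbers for weaker inhibition. For compound 1 the value given is a limit of the assay, not a measured number. The same holds for compound 2, whose value is also a limit. Compound 3 likewise shows only a limit; it stands at the limit of > 10 ug/mL in this assay, at which 3 of the 3 values shown sit, so no compound shown stands apart from the others.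

Compound 4 `O=[N+]([O-])c1cn2c(n1)[S@+]([O-])C[C@@H](OCc1ccc(OC(F)(F)F)cc1)C2` has not yet been measured in this assay. the two compounds have the same atoms and bonds and differ only in configuration as drawn: 1 of 2 stereo elements differ; a stereocentre at a sulfur is drawn S in compound 3 and R in compound 4

Within the data shown here, no step between measured compounds is available here, so no measured change accompanies a switch of configuration. For compound 4 the expectation is no shift beyond the usual scatter, giving an expected step that the limit leaves unreadable from compound 3 to compound 4. Compound 4 is therefore estimated at 15 ug/mL, within 8 ug/mL to 40 ug/mL.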

Compound 4, half-maximal inhibitory concentration: > 10 ug/mL
Compound 4: only a limit was reported; the forecaster's own chance of this, stated with the estimate: 80%; the middle value is on the limit's open side.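

Among these compounds, compound 3 and compound 4 both show only a limit in this assay, so no step between them can be read. The compounds shown leave open whether the configuration at sulfur changes cytotoxicity at all, since every value sits at one limit: the limit of > 10 ug/mL in this assay, at which 4 of the 4 values shown sit.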